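Swapping the alkyne-linked heteroaryl on the shared core

The compounds below may be only part of what the source reports. "The series", "measured", "known", "first", "only" and "open" are said of these compounds alone.

Two members of this series have been measured in a functional assay on K562 cells (Homo sapiens) for inhibition, read by MTT assay, with a stated time of 72 h; a higher number here means a weaker inhibitor, a lower number a stronger inhibitor. Compound 1 `Cc1ccc(-c2nc3ccc(N4CCN(C)CC4)cc3[nH]2)cc1C#Cc1cnc2cccnn12` gives 0.5 nM. Compound 2 `Cc1ccc(C(=O)Nc2ccc3c(c2)C(F)(F)C[C@@H]3N2CCN(C)CC2)cc1C#Cc1cnc(NC2CC2)nc1`, built on a different core but carrying the same alkyne-linked arm as the unmeasured compound that follows, gives 0.6 nM. Of the two numbers, that of compound 1 is the smaller, but the gap to compound 2 lies within the scatter of repeated measurements, so the two cannot be told apart. Going by the values given here, no step between compounds differing in one place exists among the measured pair.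

Compound 3 `Cc1ccc(-c2nc3ccc(N4CCN(C)CC4)cc3[nH]2)cc1C#Cc1cnc(NC2CC2)nc1` keeps the core of compound 1 and changes only the arm on the alkyne: a group of 10 heavy atoms (7 carbon, 3 nitrogen; one three-membered non-aromatic ring of carbon only, one six-membered aromatic ring with 2 hetero atoms) in place of a group of 9 heavy atoms (6 carbon, 3 nitrogen; one five-membered aromatic ring with 2 hetero atoms, one six-membered aromatic ring with 2 hetero atoms), on a triple-bonded carbon

Because compound 2 carries the same entering group and gives 0.6 nM, the change is expected to cost little or nothing in this assay. The step from compound 1 to compound 3 is estimated as a 1.2-fold higher number from compound 1 to compound 3 (0.08 log units; within the scatter), that is, no shift beyond the scatter in either direction. Compound 3 is therefore expected to give about 0.6 nM, with a plausible range from 0.2 nM to 2 nM.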

Compound 3, half-maximal inhibitory concentration: 1 nM
For compound 3 the middle estimate is 1.7-fold (0.22 log units) below the measured one; the measured number falls inside the stated range.
By their numbers in this assay, from the lowest: compounds 1, 2 and 3 (each within the scatter of the next).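

Going by these compounds alone, on the shared core, this is the first direct reading of the position on the triple-bonded carbon: placing 2-(cyclopropylamino)pyrimidin-5-yl there in place of the fused two-ring group of compound 1 gives a 2.0-fold higher number from compound 1 to compound 3 (0.30 log units; within the scatter) in this assay. The position therefore accepts two arms with different ring make-up, one with a three-membered carbon ring and a hydrogen-bond donor and one with neither, without a shift beyond the scatter in this assay. Nothing at hand bears on the reason for this outcome.

The compounds shown leave open whether the cyclopropyl ring or the amino hydrogen of the entering group matters at all, a question that a plain amino group, a dimethylamino group or a morpholine in place of the cyclopropylamino group would address on the same core. Also open, going by these compounds, is whether the same tolerance holds on the core of compound 2, which would take the fused two-ring arm of compound 1 in place of its 2-(cyclopropylamino)pyrimidin-5-yl group to give a one-place comparison there.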